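A few compounds are considered here, and "the series" means these few. Any claim that something is new, unique, unknown or untested is made for them only; others in the source may bear on it.

Of the compounds shown here, three of one family have been tested for their ability to stop the growth of human breast-cancer cells, measured as a functional assay on MCF7 cells (Homo sapiens) for cytotoxicity, read by MTT assay, with a stated time of 72 h; a lower number here means a stronger inhibitor of growth, a higher number a weaker inhibitor of growth. Compound 1 `C[Se]/C(=N\C(=O)c1cc2ccccc2s1)NC(=O)c1cc2ccccc2s1` gives 32700 nM. Compound 2 `O=C(/N=C(/NC(=O)c1cc(-c2ccccc2)nc2ccccc12)[Se]Cc1ccccc1)c1cc(-c2ccccc2)nc2ccccc12` gives 45600 nM, and compound 3 `C[Se]/C(=N\C(=O)c1ccno1)NC(=O)c1ccno1` gives 57500 nM. Compound 2 thus stands second highest of the three numbers, but its gaps to compound 1 and to compound 3 both lie within the ordinary scatter of repeated measurements, so the three cannot be told apart. Compound 4 `CS/C(=N\C(=O)c1cc(-c2ccccc2)nc2ccccc12)NC(=O)c1cc(-c2ccccc2)nc2ccccc12` is the next candidate; it differs from compound 2 by a group of 2 heavy atoms (1 carbon, 1 sulfur; no ring) in place of a group of 8 heavy atoms (7 carbon, 1 selenium; one six-membered aromatic ring of carbon only), on a carbon with a double bond to nitrogen. Compound 1 and compound 3, though built differently, give numbers that differ from compound 2 only within the scatter. Compound 4 is therefore expected to give about 45000 nM, somewhere between 15000 nM and 130000 nM. The change is expected to amount to a 1.0-fold lower number from compound 2 to compound 4 (0.01 log units; within the scatter), nothing beyond the scatter.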

Compound 4, concentration for total growth inhibition: 87700 nM
For compound 4 the middle estimate is 1.9-fold (0.29 log units) below the measured one; low and high end bracket the measured number.
By their numbers in this assay, from the lowest: compounds 1, 2, 3 and 4 (each within the scatter of the next, the first and the last beyond it).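

Among the compounds shown here, this is the first step in the family that changes only one place, the carbon with a double bond to nitrogen. In this assay, putting methylsulfanyl in place of the larger selenium group with its six-membered aromatic ring gives a 1.9-fold higher number from compound 2 to compound 4 (0.28 log units; within the scatter) and so removes both the ring and the selenium without a change beyond the scatter. Nothing available explains this step.

As far as these compounds go, because both features leave together, their separate contributions remain unknown. From the compounds shown here alone, whether an amine or a longer chain, such as butylsulfanyl, would be tolerated on this carbon also remains open.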